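The compounds below may be only part of what the source reports. "The series", "measured", "known", "first", "only" and "open" are said of these compounds alone.

Measured in a functional assay on MCF7 cells (Homo sapiens) for inhibition; on this read-out lower numbers stand for stronger inhibition and higher numbers for weaker inhibition:
- compound 1 `O=C(CC(CC(=O)NC1Cc2ccccc2C1)c1ccc(Cl)cc1)NCCN1CCCC1`: > 100000 nM
- compound 2 `O=C(CC(CC(=O)NC1Cc2ccccc2C1)c1ccccc1)NCCN1CCCC1`: > 100000 nM
- compound 3 `CCN(CC)CCNC(=O)CC(CC(=O)NC1Cc2ccccc2C1)c1ccccc1`: > 100000 nM

Compound 2 stands at > 100000 nM, which is a limit of the assay and not a number. All three measured compounds share one reading: the limit of > 100000 nM in this assay, at which 3 of the 3 values shown sit.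

Compound 4 `CCN(C(=O)CC(CC(=O)NCCN1CCCC1)c1ccccc1)C1Cc2ccccc2C1` is compound 2 with a single change: ethyl in place of hydrogen on an amide-type nitrogen. In plain terms, this is ethyl in place of hydrogen on an amide-type nitrogen.

Going by the values given here, two measured steps bear on this only loosely: a step that the two limits leave unreadable from compound 1 to compound 2 and a step that the two limits leave unreadable from compound 2 to compound 3. Neither alters that nitrogen, and neither has a readable size, so they offer no size or direction to carry over. Inhibition that gives a real number has not yet been seen in this small set, and compound 4 is expected to behave like compound 2. The expected change is a number no higher from compound 2 to compound 4 (the limit leaves the size open), an estimate with no direction that the data can support. For compound 4 the estimated value is 100000 nM, with an expected range from 30000 nM to 200000 nM.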

Compound 4, half-maximal inhibitory concentration: > 100000 nM
Compound 4 ended at the assay's limit; the forecaster's own chance of this, stated with the estimate: 90%; the middle value sits exactly at the limit.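

Compound 2 and compound 4 both end at a limit of the assay and not at a number, so no size or direction can be read for ethyl in place of hydrogen. The compounds shown leave open which change, if any, would give a real number in this assay at all.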